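A few compounds are considered here, and "the series" means these few. Any claim that something is new, unique, unknown or untested is made for them only; others in the source may bear on it.

In a functional assay on SK-MEL-147 cells (Homo sapiens) for cytotoxicity, read by MTT assay, with a stated time of 24 h (on this read-out higher numbers stand for an effect only at larger amounts of compound and lower numbers for an effect already at smaller amounts), compound 3 (`CCOC(=O)c1cc([Se]c2ccccc2)c2cc(Cl)ccc2n1`) gives 47100 nM. Compound 1 (`CCOC(=O)c1cc([Se]Cc2ccccc2)c2cc(OC)ccc2n1`) gives 40700 nM, which lies within the usual scatter of the result for compound 3, so the two cannot be ranked. Compound 2 (`CCCCC#Cc1cc(C(=O)OCC)nc2ccc(OC)cc12`) gives 7200 nM, a number clearly lower than either of them.

Compound 4 (`CCOC(=O)c1cc([Se]c2ccccc2)c2cc(OC)ccc2n1`) keeps the selenium-bearing group of compound 3 and differs from it in one place: methoxy in place of chloro on an aromatic carbon. Put simply, methoxy stands in place of chloro on an aromatic carbon.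

Going by the values given here, the only measured step, a 5.7-fold lower number from compound 1 to compound 2 (0.75 log units; beyond the scatter), is modest and alters the selenium-bearing group, not this place, so it says little about the present swap. Among the compounds with values here, no measured pair isolates chloro against methoxy. The nearest clue is compound 1, which carries the methoxy along with a different selenium-bearing group and, at 40700 nM, sits level with compound 3 within the scatter. This is indirect evidence, but it gives no reason to expect a real shift in this assay in either direction.

The expected change is small, a 1.2-fold lower number from compound 3 to compound 4 (0.07 log units; within the scatter), and no step beyond the scatter is anticipated. For compound 4 the estimated value is 40000 nM, with an expected range from 17000 nM to 90000 nM.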

Compound 4, half-maximal effective concentration: 33000 nM
Beside the measured number, compound 4's estimate is 1.2-fold (0.08 log units) above it; low and high end bracket the measured number.
By their numbers in this assay, from the lowest: compound 2; then compounds 4, 1 and 3 (each within the scatter of the next).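

In this assay, going by these compounds alone, the direct swap of methoxy in place of chloro on an aromatic carbon, meta to a fused ring and para to a fused ring, gives a 1.4-fold lower number from compound 3 to compound 4 (0.15 log units; within the scatter), so this pair is the first to test the change on its own, and the two groups cannot be told apart at this position. Changing the group on the selenium, with phenyl in place of benzyl, gives a 1.2-fold lower number from compound 1 to compound 4 (0.09 log units; within the scatter), so this shortening of the selenium-bearing group does not separate the two compounds either. With methoxy held fixed, the selenium-bearing group that holds a ring, in place of the ring-free group, gives a 4.6-fold higher number from compound 2 to compound 4 (0.66 log units; beyond the scatter), which confirms that the clear difference in this small set lies at that other place on the core, not at the methoxy or chloro position.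

Nothing measured here explains that difference. Also open, as far as these compounds go, is whether a group of another kind at the methoxy position, such as an amine, a carboxylic acid or a longer alkoxy chain, would move the number beyond the scatter, and whether chloro there would leave the ring-free group's lower number intact.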